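A chlorine moves on the phenyl group

A few compounds are considered here, and "the series" means these few. Any claim that something is new, unique, unknown or untested is made for them only; others in the source may bear on it.

Among the compounds with values here, in a functional assay on RAW264.7 cells (Mus musculus) for inhibition (on this read-out lower numbers stand for stronger inhibition and higher numbers for weaker inhibition), compound 2 (`CCOC(=O)C1=CCCCC1S(=O)(=O)Nc1ccccc1Cl`) gives 12 nM as the lower of the two numbers so far, and compound 1 (`CCOC(=O)C1=CCCCC1S(=O)(=O)Nc1cccc(F)c1`) gives 150 nM as the higher. Compound 3 (`CCOC(=O)C1=CCCCC1S(=O)(=O)Nc1cccc(Cl)c1`) carries 3-chlorophenyl in place of 2-chlorophenyl on a sulfonamide nitrogen. Within the data shown here, the one measured step is a 13-fold lower number from compound 1 to compound 2 (1.10 log units; beyond the scatter) and it changed the halogen and its place together, so it guides only in part. With its 3-fluorophenyl group, compound 1 at 150 nM is the closest match to compound 3, so a large step is expected. The expected change is an 8.3-fold higher number from compound 2 to compound 3 (0.92 log units; beyond the scatter) toward weaker inhibition. The expected value for compound 3 is 100 nM with 30 nM to 300 nM as its estimated range.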

Compound 3, half-maximal inhibitory concentration: 66 nM
Compound 3: middle estimate off by 1.5-fold (0.18 log units), on the high side; low and high end bracket the measured number.
By their numbers in this assay, from the lowest: compound 2; then compound 3; then compound 1.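

With the halogen held as chlorine, 3-chlorophenyl in place of 2-chlorophenyl gives a 5.5-fold higher number from compound 2 to compound 3 (0.74 log units; beyond the scatter), so the place of the chlorine matters on its own. The earlier step changed halogen and place together and could not show this. With the place held, chloro in place of fluoro gives a 2.3-fold lower number from compound 1 to compound 3 (0.36 log units; beyond the scatter), so the halogen counts as well. Nothing here explains either step. Still open, on these data alone, is how 2-fluorophenyl would compare with 2-chlorophenyl, and how a methoxyphenyl or aminophenyl group on the sulfonamide nitrogen would fare.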